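Halogen-to-nitrile step and a trifluoromethyl successor

The compounds below may be only part of what the source reports. "The series", "measured", "known", "first", "only" and "open" are said of these compounds alone.

Compound 3 `N#Cc1ccc(C(=O)Nc2ccc(S(=O)(=O)Nc3ccccc3)cc2)c(F)c1` holds the lowest number of the three measured compounds in a functional assay on HEK293 cells for agonist activity at probable G-protein coupled receptor 27 (Homo sapiens), read by a luciferase reporter and beta-arrestin recruitment, with a stated time of 10 min (on this read-out higher numbers stand for an effect only at larger amounts of compound and lower numbers for an effect already at smaller amounts), at 229 nM. Its neighbours are compound 1 `O=C(Nc1ccc(S(=O)(=O)Nc2ccccc2)cc1)c1ccc(Cl)cc1F`, with 3980 nM in this assay, and compound 2 `O=C(Nc1ccc(S(=O)(=O)Nc2ccccc2)cc1)c1ccc(I)cc1F`, with 5130 nM. The measured steps are a 17-fold lower number from compound 1 to compound 3 (1.24 log units; beyond the scatter) and a 22-fold lower number from compound 2 to compound 3 (1.35 log units; beyond the scatter), both large, while a 1.3-fold higher number from compound 1 to compound 2 (0.11 log units; within the scatter) stays within the scatter.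

Compound 4 `O=C(Nc1ccc(S(=O)(=O)Nc2ccccc2)cc1)c1ccc(C(F)(F)F)cc1F` differs from compound 3 in one place: trifluoromethyl in place of cyano on an aromatic carbon. Going by the values given here, no measured step introduces trifluoromethyl, so the relevant comparison is indirect: the two halogen analogues sit far above compound 3, and compound 3 alone carries the low number. Removing the cyano is therefore expected to move the number upward, though trifluoromethyl is neither chloro nor iodo, so the size is uncertain. The expected step is a 6.6-fold higher number from compound 3 to compound 4 (0.82 log units; beyond the scatter). Compound 4 is estimated at 1500 nM in this assay, with a range from 400 nM to 6000 nM.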

Compound 4, half-maximal effective concentration: 363 nM
Estimate against measurement, compound 4: 4.1-fold (0.62 log units) above; measured number outside the range, below it.
By their numbers in this assay, from the lowest: compounds 3 and 4 (each within the scatter of the next); then compounds 1 and 2 (each within the scatter of the next).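

In this assay, the low number at this position is not tied to the nitrile: trifluoromethyl in its place gives a 1.6-fold higher number from compound 3 to compound 4 (0.20 log units; within the scatter), so the two groups cannot be told apart here. Against the halogens, the same group gives an 11-fold lower number from compound 1 to compound 4 (1.04 log units; beyond the scatter) and a 14-fold lower number from compound 2 to compound 4 (1.15 log units; beyond the scatter), so chloro and iodo now stand apart from two different groups rather than from compound 3 alone. No measurement at hand accounts for this split between the two halogens and the other two groups.

On these data alone, whether an amine or a carboxylic acid on this aromatic carbon would stay with compound 3 and compound 4 or go with compound 1 and compound 2 remains open. Also open, as far as these compounds go, is the part played by the fluoro group, which all four compounds carry.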